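Notes on the bromo-indazole amines: ketone to alcohol

This account rests on a few compounds, and the source may have more. Where it says the series, first, only, none or still open, it means among the compounds named here.

The series shares the core of compound 1 `Oc1cccc(CNc2cc(Br)cc3[nH]ncc23)c1` and varies the group on the pendant aryl ring. In an assay for inhibition of Tryptophan 2,3-dioxygenase (Homo sapiens), with a stated time of 1 h, tested at 10 uM (a higher number here means more inhibition at the concentration tested (going by the name of the read-out), a lower number less inhibition), compound 1 gives 55%. Compound 2 `O=C(O)Nc1cccc(CNc2cc(Br)cc3[nH]ncc23)c1` carries a carbamic acid at that position; in this assay compound 2 is reported as "not active" (no number reported). Compound 3 `O=C1CCCC(Nc2cccc(CNc3cc(Br)cc4[nH]ncc34)c2)C1` carries a (3-oxocyclohexyl)amino group instead of the hydroxy; in this assay compound 3 gives 46%. Among the two numbers in hand compound 3 holds the lower one, but the step of a number 9 percentage points lower from compound 1 to compound 3 (within the scatter) lies within the scatter, so no order between compound 1 and compound 3 can be read from it.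

Compound 4 `OC1CCCC(Nc2cccc(CNc3cc(Br)cc4[nH]ncc34)c2)C1` differs from compound 3 in one place: 3-hydroxycyclohexyl in place of 3-oxocyclohexyl on a nitrogen on an aromatic ring

Among the measured compounds shown here, no measured pair in the set changes a ketone into a secondary alcohol, so the only step that bears on compound 4 at all is the one from compound 1 to compound 3, which was within the scatter. For the measured compounds named here, the carbamic acid of compound 2 is not comparable, as no single-change step links it to compound 4. The expectation for this assay is therefore a step of a number 1 percentage points lower from compound 3 to compound 4 (within the scatter), no larger than the scatter, in either direction. Compound 4 is estimated at 45%, with a range from 25% to 65%.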

Compound 4, a percentage reported as inhibition, at one concentration (the size of the read-out at that concentration, not a potency): 50%
Estimate against measurement, compound 4: 5 percentage points below; low and high end bracket the measured number.
By their numbers in this assay, from the lowest: compounds 3, 4 and 1 (each within the scatter of the next).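

Replacing 3-oxocyclohexyl with 3-hydroxycyclohexyl on a nitrogen on an aromatic ring removes the double bond outside aromatic rings and introduces a hydrogen-bond donor, yet this assay shows a number 4 percentage points higher from compound 3 to compound 4 (within the scatter) for this change, so the ketone and the alcohol cannot be told apart at this position. The comparison with the simple hydroxy group gives a number 5 percentage points lower from compound 1 to compound 4 (within the scatter) in the same assay, so neither cyclohexylamino group is separated from the hydroxy of compound 1 by the numbers in hand. Nothing available bears on why these three compounds read so closely together.

Still open, going by these compounds, is whether a change of another kind on the same nitrogen would produce a step beyond the scatter: a cyclohexyl ring carrying a primary amine or a carboxylic acid in place of the ketone or alcohol, or an open hydroxyalkyl chain in place of the ring. The carbamic acid of compound 2 has no number, so it remains unclear whether a carboxylic acid or an amide on the pendant aryl ring would behave in the same way.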